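Extending the Chain of Compound 2 by One Carbon

The compounds below may be only part of what the source reports. "The series", "measured", "known", "first", "only" and "open" are said of these compounds alone.

In an in vitro functional assay on cells for agonist activity at Bombesin receptor subtype-3 (Mus musculus), read by luminescence and calcium flux (a lower number here means that less compound is needed, a higher number that more compound is needed for the effect), compound 1 `O=C(O)c1ccccc1-c1ccc(CCc2ncc(Cc3ccc(Cl)cc3)[nH]2)cc1` gives 102 nM. Compound 2 `CCCCc1cnc(CCc2ccc(-c3ccccc3C(=O)O)cc2)[nH]1` gives 93 nM in this assay. Going by the values given here, the only measured step, a 1.1-fold lower number from compound 1 to compound 2 (0.04 log units; within the scatter), left the number essentially where it was, and compound 2 and compound 1 sit within the scatter of each other. Compound 3 `CC(C)CCc1cnc(CCc2ccc(-c3ccccc3C(=O)O)cc2)[nH]1` differs from compound 2 by methyl in place of hydrogen on a saturated chain carbon bound to two saturated chain carbons. Because a 1.1-fold lower number from compound 1 to compound 2 (0.04 log units; within the scatter) stayed within the scatter, no shift beyond the scatter is expected for compound 3, estimated at 90 nM, between 40 nM and 200 nM. The expected step is therefore a 1.0-fold lower number from compound 2 to compound 3 (0.01 log units; within the scatter).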

Compound 3, half-maximal effective concentration: 10 nM
Compound 3: middle estimate off by 9.0-fold (0.95 log units), on the high side; measured number below the stated range.
By their numbers in this assay, from the lowest: compound 3; then compounds 2 and 1 (each within the scatter of the next).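

In this assay, adding a single methyl to turn butyl into isopentyl gives a 9.3-fold lower number from compound 2 to compound 3 (0.97 log units; beyond the scatter), so this chain responds strongly to a small change, even though replacing 4-chlorophenyl with propyl had stayed within the scatter. Isobutyl in place of 4-chlorophenyl gives a 10-fold lower number from compound 1 to compound 3 (1.01 log units; beyond the scatter). Nothing available explains why this methyl matters so much. The compounds shown cannot separate the effect of the branch from that of the extra carbon, since they include no straight pentyl chain. Going by these compounds, how a larger branched group such as cyclohexyl would fare also remains open.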